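This account rests on a few compounds, and the source may have more. Where it says the series, first, only, none or still open, it means among the compounds named here.

Measured so far in a functional assay on KB cells (Homo sapiens) for inhibition; on this read-out lower numbers stand for stronger inhibition and higher numbers for weaker inhibition

compound 1 `COc1ccc(Cn2c(N)nc3cc(Cl)c(Cl)cc32)cc1` | 45000 nM
compound 2 `Clc1ccc(Cn2c(Br)nc3cc(Cl)c(Cl)cc32)cc1` | > 100000 nM (a limit)

Compound 2 stands at > 100000 nM in this assay and that is a limit of the assay, not a number. Compound 3 `COc1ccc(Cn2c(Br)nc3cc(Cl)c(Cl)cc32)cc1` differs from it in one place, where methoxy stands in place of chloro on an aromatic carbon of a six-membered aromatic ring of carbon only, para to a large group (methoxy in place of chloro on an aromatic carbon). For the measured compounds named here, no pair of measured compounds shows what this change does, so any expectation rests on little. Going by the values given here, compound 1, which also carries the methoxy, gives 45000 nM in this assay and is the only compound here with a true number. On that basis a modest step towards stronger inhibition is expected, though it may not go beyond the scatter, and compound 3 could also end at the limit of the assay. The estimated change is an at least 1.6-fold lower number from compound 2 to compound 3 (0.22 log units; that floor lies within the scatter) as an expected figure only. Compound 3 is expected near 60000 nM (estimated range 20000 nM to 120000 nM).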

Compound 3, half-maximal inhibitory concentration: 55000 nM
The estimate for compound 3 lay 1.1-fold (0.04 log units) above the measured number, within the range that was stated.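

In this assay, methoxy in place of chloro on an aromatic carbon, para to a large group, now has a step that can be read, and it gives an at least 1.8-fold lower number from compound 2 to compound 3 (0.25 log units; that floor lies within the scatter). That step is a floor only, because compound 2 stands at a limit of the assay and not at a number: the limit of > 100000 nM in this assay, at which 1 of the 3 values shown sits.

For the compounds shown here, with methoxy held fixed, bromo in place of amino on an aromatic carbon gives a 1.2-fold higher number from compound 1 to compound 3 (0.09 log units; within the scatter), so in this assay this exchange shows no difference that can be told from the scatter, which the earlier compounds could not show.

The compounds shown leave open how far the step from chloro to methoxy really reaches, and whether a hydroxyl, a methyl or a longer ether such as ethoxy at this aromatic carbon would read as methoxy does. Also open, from the compounds shown here alone, is whether amino in place of bromo on the shared core would stay as silent with chloro on the six-membered aromatic ring as it does with methoxy there.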